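One Ring Swap, Little Movement Expected

The source may hold more compounds than are shown below. What is called first, only, known or untested is meant among the compounds shown, and "the series" means these compounds.

In a functional assay on HepG2 cells (Homo sapiens) for inhibition, read by MTT assay, with a stated time of 48 h (on this read-out lower numbers stand for stronger inhibition and higher numbers for weaker inhibition), compound 1 (`CS(=O)(=O)Nc1ccc(-n2cc(COc3ccccc3Cl)nn2)cc1Oc1ccccc1`) gives 25300 nM, compound 2 (`Cc1ccc(OCc2cn(-c3ccc(NS(C)(=O)=O)c(Oc4ccccc4)c3)nn2)cc1`) gives 13000 nM, and compound 3 (`CS(=O)(=O)Nc1ccc(-n2cc(COc3ccc4ccccc4c3)nn2)cc1Oc1ccccc1`) gives 19500 nM. Compound 3 thus lies within the scatter of both others. Compound 4 (`CS(=O)(=O)Nc1ccc(-n2cc(COc3ccc(Cl)cc3)nn2)cc1Oc1ccccc1`) differs from compound 3 in one place: 4-chlorophenyl in place of naphthalen-2-yl on an oxygen on a saturated carbon. Three measured steps exchange the group at this same place: a 1.3-fold lower number from compound 1 to compound 3 (0.11 log units; within the scatter), a 1.5-fold higher number from compound 2 to compound 3 (0.18 log units; within the scatter) and a 1.9-fold lower number from compound 1 to compound 2 (0.29 log units; within the scatter). All three are small and within the scatter, so no step beyond the scatter is expected in this assay here. The estimated step is a 1.1-fold lower number from compound 3 to compound 4 (0.03 log units; within the scatter), which would also lie within the scatter. Compound 4 is expected at 18000 nM, with an estimated range from 9000 nM to 36000 nM.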

Compound 4, half-maximal inhibitory concentration: 7500 nM
Compound 4: the middle estimate sits 2.4-fold (0.38 log units) above what was measured; measured number outside the range, below it.
By their numbers in this assay, from the lowest: compounds 4, 2, 3 and 1 (each within the scatter of the next, the first and the last beyond it).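

The group on this oxygen can shift the number beyond the scatter after all: this assay shows a 2.6-fold lower number from compound 3 to compound 4 (0.41 log units; beyond the scatter) and, with 4-chlorophenyl in place of 2-chlorophenyl, a 3.4-fold lower number from compound 1 to compound 4 (0.53 log units; beyond the scatter). Chloro in place of methyl on the aromatic carbon gives only a 1.7-fold lower number from compound 2 to compound 4 (0.24 log units; within the scatter), so these two compounds cannot be told apart. No measurement here explains these steps.

From the compounds shown here alone, whether 4-fluorophenyl, or an amine or carboxylic acid on the ring, would follow compound 4 remains open. So does whether these steps hold on the core of compound 1 with other groups elsewhere.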